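The compounds below may be only part of what the source reports. "The series", "measured", "known", "first", "only" and "open" are said of these compounds alone.

Measured in a functional assay on K562 cells (Homo sapiens) for cytotoxicity, read by trypan blue exclusion, with a stated time of 96 h; a higher number here means a weaker inhibitor, a lower number a stronger inhibitor:
- compound 1 `COc1cc(OC)c(/C=C/S(=O)(=O)Nc2cc(N)c(OC)c(N)c2)c(OC)c1`: 7500 nM
- compound 2 `COc1cc(OC)c(/C=C/S(=O)(=O)Nc2ccc(OC)c(N)c2)c(OC)c1`: 3 nM

Of these two numbers, compound 2 holds the lower, 3 nM. Compound 3 `COc1ccc(NS(=O)(=O)/C=C/c2c(OC)cc(OCCCC(=O)O)cc2OC)cc1N` is the next to be read. Its difference from compound 2 is 2-carboxyethyl in place of hydrogen on a saturated chain carbon bound to an oxygen on an aromatic ring; cut one bond further out, this is methoxy to 3-carboxypropoxy.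

Within the data shown here, only one measured step exists, a 2500-fold lower number from compound 1 to compound 2 (3.40 log units; beyond the scatter). It is hydrogen in place of amino on an aromatic carbon, so it is a different kind of change at a different kind of place. Among the measured compounds shown here, it shows that a single change can move this assay a long way, but no measured step tests this place, and the range stays wide. With compound 2 at 3 nM, a rise is the likelier direction. The expected step is a 33-fold higher number from compound 2 to compound 3 (1.52 log units; beyond the scatter), smaller than the one measured. For compound 3 the estimate is 100 nM, with an expected range of 10 nM to 2000 nM.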

Compound 3, half-maximal inhibitory concentration: 10000 nM
The estimate for compound 3 lay 100-fold (2.00 log units) below the measured number; measured number outside the range, above it.
By their numbers in this assay, from the lowest: compound 2; then compounds 1 and 3 (each within the scatter of the next).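

In this assay, among these compounds, exchanging methoxy for 3-carboxypropoxy gives a 3300-fold higher number from compound 2 to compound 3 (3.52 log units; beyond the scatter), the first measured evidence that this place on the shared core is sensitive to substitution. This single change takes away the low number of compound 2 just as the amino group of compound 1 does at its own place, so compound 2 now stands beyond the scatter from both of its single-change neighbours. Nothing measured here accounts for the size of this step.

The carboxylic acid and the longer chain enter together, so the compounds shown cannot separate their contributions. A butoxy chain, the methyl ester of the same acid or a chain ending in an amine at this place would tell whether chain length or the acid goes with the rise.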